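Chloro to trifluoromethyl on compound 2

This account rests on a few compounds, and the source may have more. Where it says the series, first, only, none or still open, it means among the compounds named here.

Going by the values given here, compound 2 (`COc1ccc(C(=O)CCNc2ccc(Cl)cc2)cc1`) stands highest of the two numbers so far in an ADME assay on Vero cells (Chlorocebus sabaeus) for cytotoxicity, read by MTT assay, with a stated time of 72 h (a higher number here means a weaker inhibitor, a lower number a stronger inhibitor), at 146000 nM while compound 1 (`O=C(CCN1CCN(c2ccc([N+](=O)[O-])cc2)CC1)c1ccc(O)cc1`) reads lower at 34600 nM with the gap beyond the scatter. Compound 3 (`COc1ccc(C(=O)CCNc2ccc(C(F)(F)F)cc2)cc1`) follows from compound 2 by a single change (trifluoromethyl in place of chloro on an aromatic carbon), trifluoromethyl in place of chloro on an aromatic carbon, para to a large group. Among the compounds with values here, no measured pair carries this change yet, so the expectation rests on compound 2 at 146000 nM alone. No step beyond the scatter is expected in this assay and no firm direction can be given. The expected move is a 1.3-fold lower number from compound 2 to compound 3 (0.12 log units; within the scatter) and it stays within the scatter. For compound 3 the estimated value is 110000 nM with an expected range from 45000 nM to 250000 nM on repeated measurement.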

Compound 3, half-maximal inhibitory concentration: 32600 nM
Compound 3: middle estimate off by 3.4-fold (0.53 log units), on the high side; the whole stated range lies above it.
By their numbers in this assay, from the lowest: compounds 3 and 1 (each within the scatter of the next); then compound 2.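

On the aromatic carbon para to a large group, trifluoromethyl in place of chloro gives a 4.5-fold lower number from compound 2 to compound 3 (0.65 log units; beyond the scatter) in this assay, so the number at this position responds to this exchange. The earlier compounds shown here offered no pair differing in one place, so they could not show a change at this position alone moving the number beyond the scatter. Nothing available accounts for the size or direction of this step.

As far as these compounds go, a single pair gives one direction for one exchange, so it sets no trend for this position: whether a nitrile or a carboxylic acid on the same carbon would also lower the number remains open. Also open, from the compounds shown here alone, is whether trifluoromethyl in place of chloro would give a step of similar size on the core of compound 1.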